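The compounds below may be only part of what the source reports. "The series", "measured", "known", "first", "only" and "open" are said of these compounds alone.

Compound 1, `Cc1nn(-c2ncnc3nc[nH]c23)c2c1C(OCc1ccc(Cl)cc1Cl)CC(=O)N2`, gives 243 nM in a functional assay on HEK293 cells for agonist activity at G-protein coupled receptor 39 (Homo sapiens), read by scintillation proximity assay and inositol phosphate accumulation, with a stated time of 75 min; on this read-out lower numbers stand for an effect already at smaller amounts and higher numbers for an effect only at larger amounts of compound.
Compound 2, `Cc1nn(-c2ncnc3nc[nH]c23)c2c1C(OCc1ccccc1C#N)CC(=O)N2`, gives 127 nM in this assay.
Compound 3, `Cc1nn(-c2ncnc3nc[nH]c23)c2c1C(OC(=O)c1ccc(F)cc1)CC(=O)N2`, gives 245 nM in this assay.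

Compound 2 sits at the low end of the three numbers, yet the step of a 1.9-fold lower number from compound 1 to compound 2 (0.28 log units; within the scatter) and the step of a 1.9-fold higher number from compound 2 to compound 3 (0.29 log units; within the scatter) both remain within the scatter, so the three compounds cannot be told apart on these data. Compound 4, `Cc1nn(-c2ncnc3nc[nH]c23)c2c1C(OCCc1ccccc1)CC(=O)N2`, has not yet been measured in this assay. It differs from compound 2 in one place: benzyl in place of 2-cyanophenyl on a saturated chain carbon bound to an oxygen on a saturated carbon. For the measured compounds named here, the only measured step touching the same place is a 1.9-fold lower number from compound 1 to compound 2 (0.28 log units; within the scatter), a change of the aryl group that stayed within the scatter. No measured pair removes the nitrile alone or lengthens the chain by one carbon, so nothing shown suggests a step beyond the scatter for compound 4. Compound 4 is therefore expected to give about 200 nM in this assay, with a range of 70 nM to 600 nM. The expected step is a 1.6-fold higher number from compound 2 to compound 4 (0.20 log units; within the scatter).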

Compound 4, half-maximal effective concentration: 40 nM
The estimate for compound 4 lay 5.0-fold (0.70 log units) above the measured number; the whole stated range lies above it.
By their numbers in this assay, from the lowest: compound 4; then compounds 2, 1 and 3 (each within the scatter of the next).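

In this assay, for the compounds shown here, the group on the oxygen on a saturated carbon had so far given only steps within the scatter, but phenethyl moves the number beyond it, with a 3.2-fold lower number from compound 2 to compound 4 (0.50 log units; beyond the scatter) and with a 6.1-fold lower number from compound 1 to compound 4 (0.78 log units; beyond the scatter) as well as a 6.1-fold lower number from compound 3 to compound 4 (0.79 log units; beyond the scatter) in the same direction. The position therefore responds to this change, although swapping among 2,4-dichlorobenzyl, 2-cyanobenzyl and (4-fluorophenyl)carbonyl had shown no such step. Nothing among the data given explains why phenethyl differs from the other groups.

The change from 2-cyanobenzyl to phenethyl removes the nitrile and lengthens the chain at once, and the compounds shown do not separate these two changes. Plain benzyl, 2-cyanophenethyl or a longer chain such as 3-phenylpropyl on the same oxygen would show which of them matters and how far the trend extends.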